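This account rests on a few compounds, and the source may have more. Where it says the series, first, only, none or still open, it means among the compounds named here.

Among the measured compounds shown here, compound 1 `Cc1cc2nn(-c3ccccc3)c(N)c2c(=O)[nH]1` gives 4% in an assay on isolated protein for inhibition of ribosomal protein S6 kinase alpha-5 (Homo sapiens), read by mobility shift assay, tested at 30 uM (a higher number here means more inhibition at the concentration tested (going by the name of the read-out), a lower number less inhibition), and stands within the scatter of the only other measured number, that of compound 2 `COc1ccc(-c2cc3nn(-c4ccccc4)c(N)c3c(=O)[nH]2)cc1`, which gives 6% in this assay. For the measured compounds named here, the single measured step, a number 2 percentage points higher from compound 1 to compound 2 (within the scatter), changes a different place on the shared core. Compound 3 `Cc1[nH]c(=O)c2c(N)n(-c3ccccc3)nc2c1-c1ccccc1` differs from compound 1 by phenyl in place of hydrogen on an aromatic carbon. Going by the values given here, no measured step touches this position, and the one step known lies within the scatter, so no shift beyond the scatter is expected; compound 3 is estimated to show a step of a number 1 percentage points higher from compound 1 to compound 3 (within the scatter). Compound 3 is therefore expected at 5%, between 0% and 15%.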

Compound 3, a percentage reported as inhibition, at one concentration (the size of the read-out at that concentration, not a potency): 2%
Estimate against measurement, compound 3: 3 percentage points above; low and high end bracket the measured number.
By their numbers in this assay, from the lowest: compounds 3, 1 and 2 (each within the scatter of the next).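

In this assay, among the compounds shown here, phenyl in place of hydrogen on this aromatic carbon, ortho to a methyl group, gives a number 2 percentage points lower from compound 1 to compound 3 (within the scatter) and so provides the first measured step at this position. Adding this six-membered aromatic ring here therefore gives no sign of a gain in inhibition. No measured evidence is available to explain this result.

Still open, from the compounds shown here alone, is whether a different group on this same carbon, such as an amine or a carboxylic acid, would move the number beyond the scatter.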